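The source may report more compounds than this note shows. Statements on the series, on what has been measured and on what is new or still open speak of the compounds shown alone.

Compound 3 `COc1c(N2CCN(C/C(C)=N/NC(N)=O)C(C)C2)c(F)cc2c(=O)c(C(=O)O)cn(C3CC3)c12` stands at the top of the three numbers shown, level with compound 1 `COc1c(N2CCN(CC(C)=O)C(C)C2)c(F)cc2c(=O)c(C(=O)O)cn(C3CC3)c12`: in an ADME assay on Vero cells (Chlorocebus sabaeus) for cytotoxicity, read by MTT assay, with a stated time of 72 h (on this read-out higher numbers stand for lower toxicity in this test and lower numbers for higher toxicity in this test), compound 3 gives 500 ug/mL, while compound 1 gives 500 ug/mL. Compound 2 `CO/N=C(\C)CN1CCN(c2c(F)cc3c(=O)c(C(=O)O)cn(C4CC4)c3c2OC)CC1C` gives 49.6 ug/mL, and the step of a 10-fold higher number from compound 2 to compound 3 (1.00 log units; beyond the scatter) is the only one beyond the scatter that touches compound 3, since no change at the digits printed from compound 1 to compound 3 (within the scatter).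

Compound 4 `COc1c(N2CCN(O)C(C)C2)c(F)cc2c(=O)c(C(=O)O)cn(C3CC3)c12` differs from compound 3 by one oxygen atom in place of a group of 8 heavy atoms (4 carbon, 3 nitrogen, 1 oxygen; no ring), on an amine nitrogen in a ring. For the measured compounds named here, the steps at this ring nitrogen, no change at the digits printed from compound 1 to compound 3 (within the scatter) and a 10-fold lower number from compound 1 to compound 2 (1.00 log units; beyond the scatter), show that the group there can matter or not; no measured compound carries a hydroxy on it. He therefore expects a 1.7-fold lower number from compound 3 to compound 4 (0.22 log units; within the scatter), a small drop at most. For compound 4 he estimates 300 ug/mL, within 100 ug/mL to 500 ug/mL.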

Compound 4, half-maximal cytotoxic concentration: 19.7 ug/mL
For compound 4 the middle estimate is 15-fold (1.18 log units) above the measured one; measured number below the stated range.
By their numbers in this assay, from the lowest: compound 4; then compound 2; then compounds 1 and 3 (each within the scatter of the next).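

In this assay, hydroxy on this amine nitrogen gives the lowest number of the four compounds: a 25-fold lower number from compound 3 to compound 4 (1.40 log units; beyond the scatter), a 25-fold lower number from compound 1 to compound 4 (1.40 log units; beyond the scatter) and a 2.5-fold lower number from compound 2 to compound 4 (0.40 log units; beyond the scatter). The earlier compounds shown here showed only that changing the end of the chain on this nitrogen could leave the number unchanged or lower it, whereas compound 4 shows that replacing the whole chain with hydroxy takes it below all three. No measurement shown accounts for this drop. As far as these compounds go, it remains open whether a methyl, an ethyl or a longer chain ending in an amine on this nitrogen would stand nearer compound 4 or compound 1.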